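A chloro swap on a compound at the limit

A few compounds are considered here, and "the series" means these few. Any claim that something is new, unique, unknown or untested is made for them only; others in the source may bear on it.

Measured so far:
compound 1 `Nc1ccccc1NC(=O)CCCNCC(=O)Nc1cccc([N+](=O)[O-])c1`: > 100000 nM
compound 2 `Nc1ccccc1NC(=O)c1ccc(NCC(=O)Nc2ccc([N+](=O)[O-])cc2)cc1`: > 100000 nM

In a functional assay on U-251 cells (Homo sapiens) for inhibition, read by MTT assay, with a stated time of 2 days (a lower number here means that less compound is tolerated, a higher number that more compound is tolerated), compound 1 gives only a limit, > 100000 nM. Compound 2 also gives only a limit, > 100000 nM. Both measured compounds thus stand at the same point: the limit of > 100000 nM in this assay, at which 2 of the 2 values shown sit. Compound 3 `Nc1ccccc1NC(=O)c1ccc(NCC(=O)Nc2ccc(Cl)cc2)cc1` has chloro in place of nitro on an aromatic carbon, para to a large group: chloro in place of nitro on an aromatic carbon. Going by the values given here, no measured step shows what such a change does. A small downward move in this assay is expected, and another limit remains quite possible. The expected change is an at least 1.2-fold lower number from compound 2 to compound 3 (0.09 log units; that floor lies within the scatter). For compound 3 the estimated value is 80000 nM, with an expected range of 25000 nM to 200000 nM.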

Compound 3, concentration lethal to 50% of the cells: > 100000 nM
Compound 3: only a limit was reported; the forecaster's own chance of this, stated with the estimate: 60%; at least 1.2-fold (0.09 log units) between middle value and limit.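

Compound 3, like compound 2, gives only a limit, so the swap of nitro for chloro cannot be read as a step: the limit of > 100000 nM in this assay, at which 3 of the 3 values shown sit. The compounds shown leave open what change, if any, would give a measured number in this assay.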